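This account rests on a few compounds, and the source may have more. Where it says the series, first, only, none or still open, it means among the compounds named here.

Measured so far:
- compound 1 `Cc1ccc(N2C(=O)CS/C2=N/N=C/c2c[nH]c3ccc(Br)cc23)cc1`: 54000 nM
- compound 2 `O=C1CS/C(=N/N=C/c2c[nH]c3ccccc23)N1c1cccc2ccccc12`: 63000 nM

In an ADME assay on HaCaT cells (Homo sapiens) for inhibition, read by spectrophotometry and sulforhodamine B assay, with a stated time of 48 h (a lower number here means a stronger inhibitor of growth, a higher number a weaker inhibitor of growth), compound 1 stands level with compound 2, as the two values lie within the scatter of each other. Compound 3 `Cc1ccc(N2C(=O)CS/C2=N/N=C/c2c[nH]c3ccccc23)cc1` has not yet been measured. It differs from compound 1 by hydrogen in place of bromo on an aromatic carbon, with hydrogen in place of bromo on an aromatic carbon. For the measured compounds named here, no measured pair isolates this change, so only a small step towards a higher number is expected in this assay, hardly beyond the scatter. The expected step is a 1.1-fold higher number from compound 1 to compound 3 (0.05 log units; within the scatter). For compound 3 the estimate is 60000 nM, with an expected range of 25000 nM to 150000 nM.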

Compound 3, concentration for 50% growth inhibition: > 100000 nM
Compound 3: no number, only a limit; the forecaster's own chance of this, stated with the estimate: 15%; at least 1.6-fold (0.22 log units) between middle value and limit.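

In this assay compound 3 gives > 100000 nM, which is a limit of the assay and not a number. Hydrogen in place of bromo on this aromatic carbon provides the first single-change pair in the series, with an at least 1.8-fold higher number from compound 1 to compound 3 (0.26 log units; that floor lies within the scatter). This step is only a floor, so its true size cannot be read and the role of bromo at this position remains unsettled: the limit of > 100000 nM in this assay, at which 1 of the 3 values shown sits.

From the compounds shown here alone, whether chlorine or a methoxy group on this carbon would behave like bromo remains open. The compounds shown also leave open how the same change behaves with other groups on the ring nitrogen of the core.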